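Butyl for 2,4-difluorophenyl on the shared core

This account rests on a few compounds, and the source may have more. Where it says the series, first, only, none or still open, it means among the compounds named here.

- compound 1 `CC(=O)c1c(Nc2ccc(F)cc2F)[nH]c2c(F)cc(Cl)cc2c1=O`: > 25000 nM
- compound 2 `CC(=O)c1c(Nc2ccc(F)cc2F)[nH]c2c(F)cc(F)cc2c1=O`: > 25000 nM
- compound 3 `CC(=O)c1c(Nc2ccc(F)cc2F)[nH]c2c(Cl)cc(Cl)c(Cl)c2c1=O`: > 25000 nM

Each entry above is a limit of an ADME assay on Vero cells (Chlorocebus sabaeus) for cytotoxicity (a lower number here means that less compound is tolerated, a higher number that more compound is tolerated), and not a number. Compound 2 therefore stands only at its limit of > 25000 nM in this assay and has no exact value. Compound 4 `CCCCNc1[nH]c2c(F)cc(F)cc2c(=O)c1C(C)=O` differs from compound 2 as follows: butyl in place of 2,4-difluorophenyl on a nitrogen on an aromatic ring. The change is butyl in place of 2,4-difluorophenyl on a nitrogen on an aromatic ring. Among the measured compounds shown here, the only measured step, a step that the two limits leave unreadable from compound 1 to compound 2, has no readable size and does not involve this group. What remains is the limit of > 25000 nM in this assay, at which 3 of the 3 values shown sit. No step beyond the usual scatter is expected, and the estimated step is a step that the limit leaves unreadable from compound 2 to compound 4. For compound 4 the expected value is 30000 nM, with an estimated range of 12000 nM to 60000 nM.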

Compound 4, half-maximal cytotoxic concentration: > 25000 nM
Compound 4: no number, only a limit; the forecaster's own chance of this, stated with the estimate: 70%; the middle value is on the limit's open side.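

Compound 2 and compound 4 each give only a limit in this assay, and no step can be read between them. The compounds shown leave open whether butyl and 2,4-difluorophenyl differ at all in the concentration tolerated.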